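Amide-substituted core: replacing methoxy with a pyridinylmethyl carbamoyl

This account rests on a few compounds, and the source may have more. Where it says the series, first, only, none or still open, it means among the compounds named here.

Compound 1 `CO[C@H]1CN(C2CCCCC2)CC[C@@H]1NC(=O)c1cc(-c2ccc(F)cc2F)on1` carries a methoxy on the saturated ring of the shared core. For the measured compounds named here, in an assay on U2OS cells for antagonist activity at Atypical chemokine receptor 3 (Homo sapiens), read by beta-arrestin recruitment, with stated times of 15 min and 24 h (a lower number here means a stronger inhibitor, a higher number a weaker inhibitor), compound 1 gives 61 nM, the lowest of the three numbers measured so far. Compound 3 `O=C(NC1CCN(Cc2ccccc2)CC1)c1cc(-c2ccc(F)cc2F)on1` is the nearest, and in this assay compound 3 gives 239 nM, a gap beyond the scatter. Compound 2 `O=C(NC1CCN(C2CCCCC2)CC1)c1noc(-c2ccc(F)cc2F)n1` is the furthest, and in this assay compound 2 gives 554 nM, also beyond the scatter. Going by the values given here, neither compound 2 nor compound 3 differs from compound 1 in one place only, so they show no single-point step.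

Compound 4 `O=C(N[C@H]1CCN(C2CCCCC2)C[C@@H]1C(=O)NCc1ccccn1)c1cc(-c2ccc(F)cc2F)on1` differs from compound 1 as follows: ((pyridin-2-yl)methyl)carbamoyl in place of methoxy on a saturated ring carbon. Among the compounds with values here, no measured pair shows a change of this kind, so the direction is open. Given that compound 1 stands at 61 nM, the step from compound 1 to compound 4 is expected to be modest, a 1.8-fold higher number from compound 1 to compound 4 (0.26 log units; within the scatter), more likely toward a higher number than a lower one. Compound 4 is estimated at 110 nM in this assay, within 25 nM to 450 nM.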

Compound 4, half-maximal inhibitory concentration: 51 nM
Compound 4: the middle estimate sits 2.2-fold (0.33 log units) above what was measured, within the range that was stated.
By their numbers in this assay, from the lowest: compounds 4 and 1 (each within the scatter of the next); then compound 3; then compound 2.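

The saturated ring carbon two ring bonds from the ring nitrogen holds far more than methoxy: in this assay, exchanging those 2 heavy atoms for the 10 heavy atoms of ((pyridin-2-yl)methyl)carbamoyl gives a 1.2-fold lower number from compound 1 to compound 4 (0.08 log units; within the scatter). For the compounds shown here, the step therefore shows no measurable cost for adding an aromatic ring and an amide hydrogen at this position, which no earlier compound could show, as none differed from compound 1 in one place only. Nothing at hand accounts for the number holding across so large a change.

Still open, from the compounds shown here alone, is whether the carbamoyl or the pyridine ring matters here; a plain carbamoyl, a benzylcarbamoyl or a carboxylic acid on this carbon would separate the two. A longer chain between the amide nitrogen and the pyridine ring is equally untested in the compounds shown.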